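The compounds below may be only part of what the source reports. "The series", "measured", "known", "first", "only" and "open" are said of these compounds alone.

Working notes on the series. For the measured compounds named here, compound 1 `CCOC(=O)C1=Cc2ccccc2OC1(OCc1cn(-c2ccc(F)cc2)nn1)C(F)(F)F` is the only member with a numerical read-out: in a functional assay on MCF7 cells (Homo sapiens) for inhibition, read by MTT assay, with a stated time of 24 h (a lower number here means a stronger inhibitor, a higher number a weaker inhibitor), compound 1 gives 9100 nM. Compound 2 `CCOC(=O)C1=Cc2ccccc2OC1(OCc1cc(-c2ccc(F)cc2F)no1)C(F)(F)F` gives only a limit in this assay, > 150000 nM. Compound 3 `CCOC(=O)C1=Cc2ccccc2OC1(OCc1cc(-c2ccc(Br)cc2)no1)C(F)(F)F` likewise gives only a limit, > 150000 nM. Going by the values given here, the one measured step, a step that the two limits leave unreadable from compound 2 to compound 3, therefore tells nothing of size, since the limit of > 150000 nM in this assay, at which 2 of the 3 values shown sit, caps both ends. Compound 4 `CCOC(=O)C1=Cc2ccccc2OC1(OCc1cn(-c2ccc([N+](=O)[O-])cc2)nn1)C(F)(F)F` differs from compound 1 by nitro in place of fluoro on an aromatic carbon. Among the compounds with values here, no measured step covers this change, and the two limits cannot be read as a trend. The expectation is a step of a 1.0-fold lower number from compound 1 to compound 4 (0.00 log units; within the scatter) that stays within the usual scatter. Compound 4 is thus estimated at 9000 nM, within 3000 nM to 30000 nM.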

Compound 4, half-maximal inhibitory concentration: > 150000 nM
Compound 4: only a limit was reported; the forecaster's own chance of this, stated with the estimate: 15%; at least 16-fold (1.22 log units) between middle value and limit.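

In this assay, for the compounds shown here, nitro in place of fluoro gives the first readable step: an at least 16-fold higher number from compound 1 to compound 4 (1.21 log units; beyond the scatter). This position, on the six-membered aromatic ring of carbon only, therefore responds to the change of group, which the unreadable step between compound 2 and compound 3 could not show. The value of compound 4 is a limit and not a number: the limit of > 150000 nM in this assay, at which 3 of the 4 values shown sit.

As far as these compounds go, how far compound 4 lies past its limit stays open. Also open, from the compounds shown here alone, is whether an amine or a carboxylic acid at this position would stay close to compound 1 or also reach the limit.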